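Ethylamino replacement on the coumarin-type series: compound 4

The source may hold more compounds than are shown below. What is called first, only, known or untested is meant among the compounds shown, and "the series" means these compounds.

Measured so far:
compound 1 `CCOc1cc(=O)oc2cc(OCc3cccc(Br)c3)ccc12`: 126 nM
compound 2 `CCOC(=O)COc1cc(=O)oc2cc(OCc3cccc(Cl)c3)ccc12`: 1820 nM
compound 3 `CNC(=O)COc1cc(=O)oc2cc(OCc3cccc(Cl)c3)ccc12`: 33.9 nM

Compound 3 stands lowest of the three numbers in an assay on isolated protein (strain Sprague-Dawley) for inhibition of Amine oxidase [flavin-containing] B (Rattus norvegicus), read by spectrophotometry, with a stated time of 5 min; on this read-out higher numbers stand for weaker inhibition and lower numbers for stronger inhibition; compound 1 sits nearer to it, compound 2 furthest. Within the data shown here, the single step that changes one place only, a 54-fold lower number from compound 2 to compound 3 (1.73 log units; beyond the scatter), is large and lies at the same substituent that is now being reworked, but it alters the carbonyl end of the side chain rather than removing it.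

Compound 4 `CCNc1cc(=O)oc2cc(OCc3cccc(Cl)c3)ccc12` arises from compound 3 by ethylamino in place of (methylcarbamoyl)methoxy on an aromatic carbon. Among the measured compounds shown here, no measured pair carries this exact change. Compound 1 bears a plain ethoxy at that position and gives 126 nM, while compound 3 gives 33.9 nM; compound 1 also differs in its halogen, so those two values are only a rough pointer. The carbonyl and amide hydrogen that made the difference in the step from compound 2 to compound 3 are gone in compound 4, so a moderate rise in number is expected, though with wide uncertainty.

Compound 4 is therefore expected at 90 nM (range 20 nM to 400 nM), an expected step of a 2.7-fold higher number from compound 3 to compound 4 (0.42 log units; beyond the scatter).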

Compound 4, half-maximal inhibitory concentration: 28.2 nM
Compound 4: the middle estimate sits 3.2-fold (0.50 log units) above what was measured; the range from low to high includes it.
By their numbers in this assay, from the lowest: compounds 4 and 3 (each within the scatter of the next); then compound 1; then compound 2.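

In this assay, replacing (methylcarbamoyl)methoxy with ethylamino gives a 1.2-fold lower number from compound 3 to compound 4 (0.08 log units; within the scatter), so at this position on the aromatic carbon opposite the ring oxygen, the carbonyl of the side chain is not required to keep the number at the level of compound 3. The step of a 65-fold lower number from compound 2 to compound 4 (1.81 log units; beyond the scatter) shows that the high number of the (ethoxycarbonyl)methoxy ester is avoided by a much smaller group as well as by the methyl amide. Nothing available explains either step.

The compounds shown leave open whether the hydrogen on the ethylamino nitrogen matters, as no pair isolates it with the rest held constant. On these data alone, how dimethylamino, or a longer chain such as butylamino, would read at this position also remains open.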